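This account rests on a few compounds, and the source may have more. Where it says the series, first, only, none or still open, it means among the compounds named here.

Compound 1 `CCn1c(-c2cnc(C)nc2)nc2c(O[C@H]3CCN(C(=O)C4CC4)C3)ncnc21` gives 0.7 L/kg in an ADME assay (Canis lupus familiaris, strain Beagle) for pharmacokinetics (on this read-out lower numbers stand for narrower distribution and higher numbers for wider distribution into tissues), the lowest of the three numbers in hand; compound 2 `CCn1c(-c2cnc(C)nc2)nc2c(N[C@H]3CCN(C(=O)C4CCC4)C3)ncnc21` gives 2.3 L/kg and compound 3 `CCC(=O)N1CC[C@H](Nc2ncnc3c2nc(-c2cnc(C)nc2)n3CC)C1` gives 2.7 L/kg, each of them beyond the scatter higher than compound 1. Compound 4 `CCn1c(-c2cnc(C)nc2)nc2c(O[C@H]3CCN(C(=O)N4CC(OC)C4)C3)ncnc21` differs from compound 1 by 3-methoxyazetidin-1-yl in place of cyclopropyl on a carbonyl carbon, so that cyclopropylcarbonyl becomes (3-methoxyazetidin-1-yl)carbonyl. Among the compounds with values here, the only measured step that touches the group on that carbonyl carbon is a 1.2-fold higher number from compound 2 to compound 3 (0.07 log units; within the scatter), a change made on compounds 2 and 3 that stayed within the scatter. On that basis no step beyond the scatter is expected for compound 4, an estimated no change at the digits printed from compound 1 to compound 4 (within the scatter). Compound 4 is therefore expected to give about 0.7 L/kg, with a range from 0.4 L/kg to 1.3 L/kg.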

Compound 4, volume of distribution: 2.3 L/kg
Beside the measured number, compound 4's estimate is 3.3-fold (0.52 log units) below it; measured number outside the range, above it.
By their numbers in this assay, from the lowest: compound 1; then compounds 2, 4 and 3 (each within the scatter of the next).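

In this assay, within the data shown here, the group on the carbonyl carbon turns out to matter at this position: 3-methoxyazetidin-1-yl in place of cyclopropyl gives (a 3.3-fold higher number from compound 1 to compound 4 (0.52 log units; beyond the scatter)), whereas the only earlier step there, (a 1.2-fold higher number from compound 2 to compound 3 (0.07 log units; within the scatter)), did not show this. The data give no measured reason for this step.

From the compounds shown here alone, it remains open whether the step belongs to the azetidine ring or to its methoxy group, and what a plain azetidin-1-yl or a morpholin-4-yl would give on that carbonyl carbon. Going by these compounds, it is also open whether the same change would have the same size on compound 2.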